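This account rests on a few compounds, and the source may have more. Where it says the series, first, only, none or still open, it means among the compounds named here.

Compound 1 `Cc1ccc2[nH]c(=O)c(-c3nc4ccccc4[nH]3)cc2c1` gives only a limit in a functional assay on BEL-7404 cells for cytotoxicity against BEL-7404 tumor cell line (Homo sapiens), read by MTT assay, with a stated time of 48 h (a higher number here means a weaker inhibitor, a lower number a stronger inhibitor), namely > 100000 nM.
Compound 2 `Cc1cc2nc(-c3cc4ccccc4[nH]c3=O)[nH]c2cc1C` likewise gives only a limit in this assay, namely > 100000 nM.
Compound 3 `O=c1[nH]c2ccccc2cc1-c1nc2cc(Br)ccc2[nH]1` gives a number in this assay, 14500 nM.

Compound 2 therefore stands at the limit rather than at a measured number, and the limit of > 100000 nM in this assay, at which 2 of the 3 values shown sit, shows that the same is true of most of what has been measured so far; only compound 3 returns a number, and it is a weak one. Going by the values given here, no two measured compounds differ in just one place, so no measured step can guide the change from compound 2 to compound 4 `COc1ccc2[nH]c(=O)c(-c3nc4cc(C)c(C)cc4[nH]3)cc2c1`. The change is methoxy in place of hydrogen on an aromatic carbon.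

With nothing measured on either side of that change, no direction is expected beyond the scatter in this assay, and the estimated step of an at least 1.1-fold lower number from compound 2 to compound 4 (0.04 log units; that floor lies within the scatter) is held close to none. Compound 4 is expected to give about 90000 nM in this assay, within 20000 nM to 300000 nM, because compound 2 already sits at > 100000 nM and a fresh limit is the likeliest outcome.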

Compound 4, half-maximal inhibitory concentration: > 100000 nM
Compound 4 was reported as a limit; the forecaster's own chance of this, stated with the estimate: 60%; middle value at least 1.1-fold (0.04 log units) from the limit.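

Compound 2 and compound 4 are both reported only as limits, so no step between them can be read, and the one fact that stands is: the limit of > 100000 nM in this assay, at which 3 of the 4 values shown sit.

The compounds shown leave open whether methoxy in place of hydrogen on an aromatic carbon changes the read-out in this assay at all.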